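The compounds below may be only part of what the source reports. "The series", "measured", "known", "first", "only" and "open" are said of these compounds alone.

Measured compounds:
compound 1, `O=C(O)CC/C=C\CC1COC(c2ccc([N+](=O)[O-])cc2)OC1c1cccnc1`, in an assay for inhibition of prostacyclin synthase (Homo sapiens), using microsomes; on this read-out higher numbers stand for weaker inhibition and lower numbers for stronger inhibition: 13000 nM
compound 2, `Cc1ccc(C#N)c(OC(C)(C)C2OCC(C/C=C\CCC(=O)O)C(c3cccnc3)O2)c1`: > 100000 nM
compound 3, `CC(C)(Oc1ccccc1[N+](=O)[O-])C1OCC(C/C=C\CCC(=O)O)C(c2cccnc2)O1`: < 1000 nM

Among the measured compounds shown here, compound 1 holds the only plain number in this assay. The value of compound 2 is a limit of the assay, (the limit of > 100000 nM in this assay, at which 1 of the 3 values shown sits). The value of compound 3 is likewise a limit, (the limit of < 1000 nM in this assay, at which 1 of the 3 values shown sits). For the measured compounds named here, the one measured step joins these two limits: an at least 100-fold lower number from compound 2 to compound 3 (2.00 log units; beyond the scatter); it shows that the group carried on the saturated ring carbon of the shared core can move the read-out strongly.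

Compound 4, `CC(C)(Cc1ccccc1)C1OCC(C/C=C\CCC(=O)O)C(c2cccnc2)O1`, is not yet measured. It differs from compound 1 by 1-benzyl-1-methylethyl in place of 4-nitrophenyl on a saturated ring carbon. Going by the values given here, no measured step covers this exact exchange, and compound 1 itself has no partner in a step, so the size of the change from compound 1 to compound 4 can only be guessed by analogy with the wide spread between compound 2 and compound 3. The expectation for compound 4 is a modest move toward a lower number, a 2.6-fold lower number from compound 1 to compound 4 (0.41 log units; beyond the scatter), with a broad range. Compound 4 is estimated at 5000 nM, within 700 nM to 35000 nM.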

Compound 4, half-maximal inhibitory concentration: 13000 nM
The estimate for compound 4 lay 2.6-fold (0.41 log units) below the measured number; measured number inside the range.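

In this assay, the exchange on the saturated ring carbon reads no change at the digits printed from compound 1 to compound 4 (within the scatter), so the 4-nitrophenyl of compound 1 and the 1-benzyl-1-methylethyl of compound 4, though differing in atoms and hydrogen-bond acceptors, give the same printed number. The group on the saturated chain carbon matters more, as compound 4 falls between the two earlier compounds: an at least 13-fold higher number from compound 3 to compound 4 (1.11 log units; beyond the scatter), and an at least 7.6-fold lower number from compound 2 to compound 4 (0.88 log units; beyond the scatter). Both steps are open-ended, since the values of compound 2 and compound 3 are each a limit of the assay rather than a number.

The compounds shown leave open how far compound 3 lies from its limit. They also leave open whether an amine on the benzyl group, or a longer chain in place of benzyl, would move the read-out.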